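The source may hold more compounds than are shown below. What is called first, only, known or untested is meant among the compounds shown, and "the series" means these compounds.

Working notes on the series. The measure throughout is a functional assay on BGC-823 cells (Homo sapiens) for inhibition, read by MTT assay, with a stated time of 72 h; a lower number here means a stronger inhibitor, a higher number a weaker inhibitor. Compound 1, `C[C@@H]1CCN(c2cc(-c3ccccc3)nc3ncnn23)C[C@@H]1N(C)c1ncnc2[nH]ccc12`, gives only a limit of the assay in this assay, > 100000 nM, and no number. Compound 2, `Cc1cc(N2CC[C@@H](C)[C@@H](N(C)c3ncnc4[nH]ccc34)C2)n2nc(SCc3ccccc3Br)nc2n1`, gives 81100 nM in this assay. Among the measured compounds shown here, that is the only number in the set so far; the one other value is a limit, and compound 2 therefore stands alone as the single point from which any estimate must start, with no step between measured compounds to show how a change at the sulfur-bound chain moves the read-out. The relevant boundary is the limit of > 100000 nM in this assay, at which 1 of the 2 values shown sits.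

Compound 3, `Cc1cc(N2CC[C@@H](C)[C@@H](N(C)c3ncnc4[nH]ccc34)C2)n2nc(SCCCc3ccccc3)nc2n1`, is not yet measured in this assay. Its change from compound 2 is phenethyl in place of 2-bromophenyl on a saturated chain carbon bound to a sulfur. The two groups are of the same size class and both carry one six-membered aromatic ring of carbon only, with no donors or acceptors in either; the chain grows by one carbon and the bromine is lost. For the measured compounds named here, with no measured step to lean on, the expectation is a step of a 1.0-fold lower number from compound 2 to compound 3 (0.01 log units; within the scatter), no larger than the scatter, in no firm direction. Compound 3 is estimated at 80000 nM in this assay, expected between 30000 nM and 200000 nM, with a real chance that only a limit is returned.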

Compound 3, half-maximal inhibitory concentration: > 100000 nM
Compound 3: no number, only a limit; the forecaster's own chance of this, stated with the estimate: 40%; at least 1.2-fold (0.09 log units) between middle value and limit.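

Among the compounds shown here, at the sulfur-bound position, the first step in this assay is an at least 1.2-fold higher number from compound 2 to compound 3 (0.09 log units; that floor lies within the scatter), with 3-phenylpropyl taking the place of 2-bromobenzyl when the same difference is cut one bond further out. This step is only a floor, set by a limit of the assay, and that floor lies within the scatter, so it shows no size or firm direction for the change. What is new is that a second group at this position also returns a limit and no number, leaving compound 2 as the only compound with a number and adding to the values that rest at one boundary: the limit of > 100000 nM in this assay, at which 2 of the 3 values shown sit.

The change combines the loss of the bromine with growth of the chain, and these two parts cannot be told apart here; an unsubstituted benzyl on the sulfur would separate them. As far as these compounds go, it also remains open whether the number can be brought down at this position by a group of a different kind, such as a chain ending in an amine or a carboxylic acid.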